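This account rests on a few compounds, and the source may have more. Where it says the series, first, only, none or still open, it means among the compounds named here.

Compound 1 `N#Cc1c(-c2ccccc2Cl)c(C#N)c(=O)n(/N=C/c2cn(-c3ccccc3)nc2-c2ccccc2)c1N`: 84 ug/mL
Compound 2 `N#Cc1c(-c2cccc([N+](=O)[O-])c2)c(C#N)c(=O)n(/N=C/c2cn(-c3ccccc3)nc2-c2ccccc2)c1N`: 124 ug/mL

In an ADME assay on NIH3T3 cells (Mus musculus) for cytotoxicity, read by MTT assay (a lower number here means a stronger inhibitor, a higher number a weaker inhibitor), compound 2 gives 124 ug/mL, the higher of the two figures, but only by a 1.5-fold higher number from compound 1 to compound 2 (0.17 log units; within the scatter), which is within the scatter. Compound 3 `N#Cc1c(-c2ccc(Br)cc2)c(C#N)c(=O)n(/N=C/c2cn(-c3ccccc3)nc2-c2ccccc2)c1N` has not been measured. It differs from compound 2 by 4-bromophenyl in place of 3-nitrophenyl on an aromatic carbon. Among the measured compounds shown here, the one measured step at this position, a 1.5-fold higher number from compound 1 to compound 2 (0.17 log units; within the scatter), exchanged one aryl group for another without moving the number beyond the scatter, so no step beyond the scatter is expected in this assay for this change either. Compound 3 is therefore expected to give 110 ug/mL, between 55 ug/mL and 220 ug/mL, a step of a 1.1-fold lower number from compound 2 to compound 3 (0.05 log units; within the scatter).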

Compound 3, half-maximal inhibitory concentration: > 200 ug/mL
Compound 3: no number, only a limit (the forecaster's own chance of this, stated with the estimate: 5%); middle value at least 1.8-fold (0.25 log units) from the limit.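

In this assay compound 3 gives > 200 ug/mL, which is a limit of the assay and not a number. On these data alone, exchanging one aryl group for another at this position can therefore move the number beyond the scatter: 4-bromophenyl in place of 2-chlorophenyl gives an at least 2.3-fold higher number from compound 1 to compound 3 (0.37 log units; beyond the scatter), while 4-bromophenyl in place of 3-nitrophenyl gives an at least 1.6-fold higher number from compound 2 to compound 3 (0.20 log units; that floor lies within the scatter), a floor whose true size stays unknown. Only compound 3 reaches this ceiling: the limit of > 200 ug/mL in this assay, at which 1 of the 3 values shown sits.

As far as these compounds go, how far compound 3 lies past the limit remains open. So does whether the bromine itself matters, and how a phenyl ring carrying an amine or a carboxylic acid would read.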